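Swapping an Aminophenyl for a Methoxypyridyl Ring

A few compounds are considered here, and "the series" means these few. Any claim that something is new, unique, unknown or untested is made for them only; others in the source may bear on it.

Compound 1, `CNc1nc(NCCCN(C)C)c2sc(-c3ccc(N)cc3)cc2n1`: 2.3
Compound 2, `CNc1nc(NCCCN(C)C)c2sc(-c3ccc(S(C)(=O)=O)cc3)cc2n1`: 2.1
Compound 3, `CNc1nc(NCCCN(C)C)c2sc(-c3ccc(NS(C)(=O)=O)cc3)cc2n1`: 2.1

These three compounds share one core and differ only in the group on the outer aromatic ring, each measured in a physicochemical assay for lipophilicity, read by HPLC, at pH 7.4; a higher number here means a more lipophilic compound, a lower number a more polar compound. Compound 1 gives 2.3; from it, a number 0.20 log units lower from compound 1 to compound 2 (within the scatter) and a number 0.20 log units lower from compound 1 to compound 3 (within the scatter), while no change at the digits printed from compound 2 to compound 3 (within the scatter). All three values thus sit within the scatter of one another, and none stands apart.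

Compound 4, `CNc1nc(NCCCN(C)C)c2sc(-c3ccc(OC)nc3)cc2n1`, is not yet measured. Its change from compound 1 is 6-methoxypyridin-3-yl in place of 4-aminophenyl on an aromatic carbon. For the measured compounds named here, no measured step covers a change of this kind; the measured steps only show that varying the group on that ring moved the value little. A small step is therefore expected, a number 0.20 log units higher from compound 1 to compound 4 (within the scatter). The value of compound 4 is estimated at 2.5, within 2 to 3.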

Compound 4, distribution coefficient: 2.8
Compound 4: middle estimate off by 0.30 log units, on the low side; measured number inside the range.
By their numbers in this assay, from the lowest: compounds 2, 3 and 1 (each within the scatter of the next); then compound 4.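

In this assay, for the compounds shown here, exchanging the whole ring at this position gives a number 0.50 log units higher from compound 1 to compound 4 (beyond the scatter), the only step here beyond the scatter, so this place on the shared core can register a change, though the variations among compounds 1, 2 and 3 did not show it. The exchange alters the ring atoms and the attached group together. Nothing measured here explains the step.

Whether the ring nitrogen or the methoxy group accounts for the step stays open. A 4-methoxyphenyl ring or an unsubstituted pyridine ring on the same core would separate the two.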